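The source may report more compounds than this note shows. Statements on the series, on what has been measured and on what is new or still open speak of the compounds shown alone.

In a functional assay on BCG823 cells (Homo sapiens) for antiproliferative activity, read by MTT assay, with a stated time of 48 h (a higher number here means a weaker inhibitor, a lower number a stronger inhibitor), compound 1 `CN1CCN(CCCOc2c(OCc3ccccc3)cc3oc(-c4ccccc4)cc(=O)c3c2O)CC1` gives 4100 nM and compound 2 `CN(C)CCCOc1c(OCc2ccccc2)cc2oc(-c3ccccc3)cc(=O)c2c1O` gives 5500 nM. These two numbers lie within the scatter of each other, so compound 2 stands level with compound 1 and the pair cannot be ranked. Compound 3 `O=c1cc(-c2ccccc2)oc2cc(OCc3ccccc3)c(OCCCCN3CCCC3)c(O)c12` keeps the shared core and differs from compound 2 at the end of the chain: (pyrrolidin-1-yl)methyl in place of dimethylamino on a saturated chain carbon, three bonds along the chain from an oxygen on an aromatic ring. Put another way, 3-(dimethylamino)propyl gives way to 4-(pyrrolidin-1-yl)butyl. Going by the values given here, only one measured step bears on this change: a 1.3-fold higher number from compound 1 to compound 2 (0.13 log units; within the scatter). It places dimethylamino where 4-methylpiperazin-1-yl stood, on the same chain carbon, and stays within the scatter. Among the compounds with values here, no measured compound carries the 4-(pyrrolidin-1-yl)butyl group, so this single step is thin evidence and the range must stay wide. The expectation in this assay is therefore no step beyond the scatter, in either direction. The expected size is a 1.2-fold lower number from compound 2 to compound 3 (0.09 log units; within the scatter). For compound 3 the estimated value is 4500 nM, with an expected range from 1600 nM to 12000 nM.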

Compound 3, half-maximal inhibitory concentration: 3200 nM
Compound 3: the middle estimate sits 1.4-fold (0.15 log units) above what was measured, and the stated range covers the measured number.
By their numbers in this assay, from the lowest: compounds 3, 1 and 2 (each within the scatter of the next).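

In this assay, the end of this chain takes a clearly different group with no step beyond the scatter: replacing dimethylamino with (pyrrolidin-1-yl)methyl on the saturated chain carbon gives a 1.7-fold lower number from compound 2 to compound 3 (0.24 log units; within the scatter), and the same group in place of 4-methylpiperazin-1-yl gives a 1.3-fold lower number from compound 1 to compound 3 (0.11 log units; within the scatter). The earlier pair showed only that two amines on a three-carbon chain could not be told apart, whereas compound 3 extends this to the longer 4-(pyrrolidin-1-yl)butyl group with its five-membered ring, so all three compounds stand level and cannot be ranked. Nothing measured alongside these numbers offers an explanation for this tolerance.

Because the step from compound 2 to compound 3 alters the amine and the chain end together, the compounds shown cannot separate the two changes, and 3-(pyrrolidin-1-yl)propyl would be the group that divides them. All three chains also end in an amine, which leaves open how a chain ending in a hydroxyl group or a carboxylic acid would compare, or a shorter chain such as 2-(dimethylamino)ethyl.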